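Swapping Pyrimidine for Methylpyrazole on a Weakly Active Core

The compounds below may be only part of what the source reports. "The series", "measured", "known", "first", "only" and "open" are said of these compounds alone.

Compound 1 `CCN(c1ccc(C#N)c(Cl)c1)c1cc(-c2cncnc2)ccc1C`: > 30000 nM
Compound 2 `CCN(c1cccc(-c2ccccc2)c1)c1ccc(C#N)c(Cl)c1`: "not determined" (no result reported)
Compound 3 `CCN(c1cccc(-c2cncnc2)c1)c1ccc(C#N)c(Cl)c1`: > 30000 nM

In a functional assay on CWR22R cells (Homo sapiens) for antiproliferative activity, read by CCK-8 assay, with a stated time of 6 days (on this read-out lower numbers stand for stronger inhibition and higher numbers for weaker inhibition), compound 1 reaches only the assay limit, not a measured number. Compound 3 likewise stands at a limit. Compound 2 has no reported result. Going by the values given here, the one measured step, a step that the two limits leave unreadable from compound 1 to compound 3, is therefore unreadable in size, and the direction of the change from compound 1 onward cannot be read from it.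

Compound 4 `CCN(c1ccc(C#N)c(Cl)c1)c1cc(-c2ccnn2C)ccc1C` differs from compound 1 by 1-methyl-1H-pyrazol-5-yl in place of pyrimidin-5-yl on an aromatic carbon. Among the compounds with values here, no measured step bears on this change, so no size can be read from the data. Given (the limit of > 30000 nM in this assay, at which 2 of the 3 values shown sit), compound 4 is expected to stay at the limit as well, estimated at 40000 nM with a range of 10000 nM to 150000 nM, which means an expected step that the limit leaves unreadable from compound 1 to compound 4.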

Compound 4, half-maximal inhibitory concentration: 4330 nM
Beside the measured number, compound 4's estimate is 9.2-fold (0.97 log units) above it; measured number outside the range, below it.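

In this assay this position on the shared core proves sensitive to the group it carries: 1-methyl-1H-pyrazol-5-yl in place of pyrimidin-5-yl gives an at least 6.9-fold lower number from compound 1 to compound 4 (0.84 log units; beyond the scatter) and yields the only measured number among the compounds shown. The two groups match in heavy atoms, hydrogen-bond donors and acceptors, so those counts alone do not separate them. The step is only a minimum, since compound 1 stands at a limit of the assay: the limit of > 30000 nM in this assay, at which 2 of the 4 values shown sit.

Still open, as far as these compounds go, is whether the five-membered ring or its methyl group matters more. Also open, from the compounds shown here alone, is whether an unmethylated pyrazole or a ring carrying an amine would retain this activity.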